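This account rests on a few compounds, and the source may have more. Where it says the series, first, only, none or still open, it means among the compounds named here.

In a functional assay on A549 cells (Homo sapiens) for inhibition, read by MTT assay, with a stated time of 72 h (on this read-out lower numbers stand for stronger inhibition and higher numbers for weaker inhibition), three compounds have been measured so far. Compound 1 `O=C1Nc2ccccc2/C1=N/NC(=S)N1CCN(c2ccccc2)CC1` gives 18600 nM, compound 2 `O=C1Nc2c(Br)cc(Br)cc2/C1=N/NC(=S)N1CCN(c2ccccc2)CC1` gives 6110 nM, and compound 3 `COc1ccc(N2CCN(C(=S)N/N=C3\C(=O)Nc4ccc(Cl)cc43)CC2)cc1` gives 7680 nM. Compound 3 thus holds the second highest of the three numbers: its value lies within the scatter of compound 2, while compound 1 sits beyond the scatter at a higher, weaker number. Compound 4 `O=C1Nc2ccc(Cl)cc2/C1=N/NC(=S)N1CCN(c2ccccc2[N+](=O)[O-])CC1` has not yet been measured. It differs from compound 3 in one place: 2-nitrophenyl in place of 4-methoxyphenyl on an amine nitrogen in a ring. Among the measured compounds shown here, no measured pair shows what this exchange on the amine nitrogen in a ring does, so for compound 4 the expected step is a 1.0-fold higher number from compound 3 to compound 4 (0.02 log units; within the scatter), nothing beyond the scatter in either direction. Compound 4 is therefore estimated at 8000 nM, between 3000 nM and 22000 nM.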

Compound 4, half-maximal inhibitory concentration: 5580 nM
The estimate for compound 4 lay 1.4-fold (0.16 log units) above the measured number; the measured number falls inside the stated range.
By their numbers in this assay, from the lowest: compounds 4, 2 and 3 (each within the scatter of the next); then compound 1.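

In this assay, among the compounds shown here, this is the first exchange read on the amine nitrogen in a ring: 2-nitrophenyl in place of 4-methoxyphenyl gives a 1.4-fold lower number from compound 3 to compound 4 (0.14 log units; within the scatter), so the two groups cannot be told apart here. At this position, the change from a methoxy group to a nitro group, including where each sits on the phenyl ring, leaves the number within the scatter. Nothing available here accounts for this result. Still open, as far as these compounds go, is whether an amine or a carboxylic acid on that phenyl ring, or a longer chain in its place, would move the number beyond the scatter.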